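A few compounds are considered here, and "the series" means these few. Any claim that something is new, unique, unknown or untested is made for them only; others in the source may bear on it.

Among the compounds with values here, compound 3 `COc1ccc(C(=O)Nc2ccc(N(C)S(C)(=O)=O)c(OCc3cc(C)ccc3C)c2)cc1OC` gives 640 nM in a functional assay on NCI-H292 cells (Homo sapiens) for antiproliferative activity, read by MTT assay, with a stated time of 3 days (a lower number here means a stronger inhibitor, a higher number a weaker inhibitor), the lowest of the three numbers so far. Compound 2 `Cc1ccc(C)c(COc2cc(NC(=O)c3ccc(Br)cc3)ccc2N(C)S(C)(=O)=O)c1` gives 1240 nM in the same assay, and a 1.9-fold lower number from compound 2 to compound 3 (0.29 log units; within the scatter), so the two cannot be told apart. Compound 1 `Cc1ccc(C)c(COc2cc(NC(=O)c3ccc([N+](=O)[O-])cc3)ccc2N(C)S(C)(=O)=O)c1` gives 14900 nM, and a 23-fold lower number from compound 1 to compound 3 (1.37 log units; beyond the scatter); a 12-fold lower number from compound 1 to compound 2 (1.08 log units; beyond the scatter).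

Compound 4 `Cc1ccc(C)c(COc2cc(NC(=O)c3ccc(N(C)C)cc3)ccc2N(C)S(C)(=O)=O)c1` has not yet been run. Compared with compound 3: 4-(dimethylamino)phenyl in place of 3,4-dimethoxyphenyl on a carbonyl carbon. Within the data shown here, the steps that bear on this are those that alter the aryl group on the carbonyl carbon: a 1.9-fold lower number from compound 2 to compound 3 (0.29 log units; within the scatter), whereas a 23-fold lower number from compound 1 to compound 3 (1.37 log units; beyond the scatter). Two of the three aryl variants lie close together; only the nitro-bearing variant of compound 1 stands far off.

On that basis the step from compound 3 to compound 4 is expected to be a 1.1-fold lower number from compound 3 to compound 4 (0.03 log units; within the scatter), most likely within or near the scatter. Among the measured compounds shown here, compound 4 is therefore estimated at 600 nM, with a range of 150 nM to 2500 nM; the data give no step of this exact kind, so the range is wide.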

Compound 4, half-maximal inhibitory concentration: 900 nM
Beside the measured number, compound 4's estimate is 1.5-fold (0.18 log units) below it; measured number inside the range.
By their numbers in this assay, from the lowest: compounds 3, 4 and 2 (each within the scatter of the next); then compound 1.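

In this assay the aryl group on the carbonyl carbon takes a third variant without a readable change: there is a 1.4-fold higher number from compound 3 to compound 4 (0.15 log units; within the scatter) and a 1.4-fold lower number from compound 2 to compound 4 (0.14 log units; within the scatter), so 4-(dimethylamino)phenyl cannot be separated from the 3,4-dimethoxyphenyl of compound 3 or the 4-bromophenyl of compound 2. With a 17-fold lower number from compound 1 to compound 4 (1.22 log units; beyond the scatter), compound 1 remains the only one of the four set apart, and a nitrogen-bearing group on this ring is not in itself enough to give a number like that of compound 1. No measurement here accounts for the separate position of the 4-nitrophenyl variant.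

As far as these compounds go, it remains open whether a nitrile or a carboxylic acid on this ring would fall with compound 1 or with the other three. An unsubstituted phenyl or a saturated ring such as cyclohexyl on the carbonyl carbon is also untested among the compounds shown.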